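Anilino variation on a sulfonamide-capped series: compound 4

The source may report more compounds than this note shows. Statements on the series, on what has been measured and on what is new or still open speak of the compounds shown alone.

Three compounds share one core and differ only in the aryl group on a nitrogen on an aromatic ring. Compound 1 `COc1cc2ncnc(Nc3cccc(F)c3)c2cc1OCCCCC(=O)Nc1ccc(S(N)(=O)=O)cc1` carries 3-fluorophenyl, compound 2 `COc1ccc(Nc2ncnc3cc(OC)c(OCCCCC(=O)Nc4ccc(S(N)(=O)=O)cc4)cc23)cc1OC` 3,4-dimethoxyphenyl, compound 3 `COc1cc2ncnc(Nc3ccc(OC(F)(F)F)cc3)c2cc1OCCCCC(=O)Nc1ccc(S(N)(=O)=O)cc1` 4-(trifluoromethoxy)phenyl. In a functional assay on A549 cells (Homo sapiens) for antiproliferative activity, read by MTT assay, with a stated time of 72 h (a higher number here means a weaker inhibitor, a lower number a stronger inhibitor), compound 1 gives only a limit, > 40000 nM. Compound 2 likewise gives only a limit, > 40000 nM. Compound 3 too gives only a limit, > 40000 nM. Hence compound 3 stands nowhere readable: the steps a step that the two limits leave unreadable from compound 1 to compound 2, a step that the two limits leave unreadable from compound 1 to compound 3 and a step that the two limits leave unreadable from compound 2 to compound 3 cannot be sized, since every value sits at the limit of > 40000 nM in this assay, at which 3 of the 3 values shown sit. Compound 4 `COc1cc2ncnc(Nc3cccc(C)c3)c2cc1OCCCCC(=O)Nc1ccc(S(N)(=O)=O)cc1` brings (3-methylphenyl in place of 4-(trifluoromethoxy)phenyl on a nitrogen on an aromatic ring). With no readable step to draw on, the expected step that the limit leaves unreadable from compound 3 to compound 4 is a guess anchored at the limit. Compound 4 is thus expected near 50000 nM, from 15000 nM to 200000 nM.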

Compound 4, half-maximal inhibitory concentration: 16000 nM
Estimate against measurement, compound 4: 3.1-fold (0.49 log units) above; low and high end bracket the measured number.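

In this assay, 3-methylphenyl on this nitrogen is the only one of the four aryl groups that gives a readable value, with an at least 2.5-fold lower number from compound 3 to compound 4 (0.39 log units; beyond the scatter), an at least 2.5-fold lower number from compound 2 to compound 4 (0.39 log units; beyond the scatter) and an at least 2.5-fold lower number from compound 1 to compound 4 (0.39 log units; beyond the scatter). The last of these is methyl in place of fluoro on an aromatic carbon, so this single substituent change is enough to move the compound off the limit. Each step gives only a minimum size because the other three compounds remain at a limit: the limit of > 40000 nM in this assay, at which 3 of the 4 values shown sit.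

Open, from the compounds shown here alone, is whether chloro or ethyl in place of that methyl would keep a readable value. Also open, going by these compounds, is whether the 3-methylphenyl gain would persist with a carboxylic acid in place of the sulfonamide.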